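The source may hold more compounds than are shown below. What is called first, only, known or untested is meant among the compounds shown, and "the series" means these compounds.

Compound 1 `CC(C)(C)c1ccc(CNCCNS(=O)(=O)c2cc(C(F)(F)F)cc(C(F)(F)F)c2)cc1`: 14000 nM
Compound 2 `O=S(=O)(NCCCNCc1ccc(Cl)cc1)c1cc(C(F)(F)F)cc(C(F)(F)F)c1`: 1800 nM
Compound 3 `O=S(=O)(NCCCNCc1ccc(C(F)(F)F)cc1)c1cc(C(F)(F)F)cc(C(F)(F)F)c1`: 2800 nM

Among these three, compound 2 gives the lowest number in a functional assay on A2780 cells (Homo sapiens) for inhibition, read by MTT assay, with a stated time of 72 h; on this read-out lower numbers stand for stronger inhibition of growth and higher numbers for weaker inhibition of growth. Compound 3 sits close to it, the step between them being a 1.6-fold higher number from compound 2 to compound 3 (0.19 log units; within the scatter), whereas compound 1 lies far from compound 2, beyond the scatter.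

Compound 4 `O=S(=O)(NCCCNCc1ccc(Cl)c(C(F)(F)F)c1)c1cc(C(F)(F)F)cc(C(F)(F)F)c1` differs from compound 2 in one place: trifluoromethyl in place of hydrogen on an aromatic carbon. Going by the values given here, the only measured step on this ring exchanges one group for another rather than adding one, and it is small: a 1.6-fold higher number from compound 2 to compound 3 (0.19 log units; within the scatter). Among the compounds with values here, an added trifluoromethyl with the chloro group retained has no measured counterpart here. Given this, compound 4 is expected to show a step of a 1.1-fold higher number from compound 2 to compound 4 (0.05 log units; within the scatter). The estimate for compound 4 in this assay is 2000 nM, between 900 nM and 4500 nM.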

Compound 4, concentration for 50% growth inhibition: 5900 nM
The estimate for compound 4 lay 3.0-fold (0.47 log units) below the measured number; the measured number lies above the stated range.
By their numbers in this assay, from the lowest: compounds 2 and 3 (each within the scatter of the next); then compound 4; then compound 1.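

In this assay, adding trifluoromethyl at this place, ortho to a chloro group, brings a 3.3-fold higher number from compound 2 to compound 4 (0.52 log units; beyond the scatter), towards weaker inhibition of growth. The ring change that keeps trifluoromethyl and adds the chloro group brings a 2.1-fold higher number from compound 3 to compound 4 (0.32 log units; beyond the scatter), so this is the first change on this ring shown to go beyond the scatter. Nothing available on these compounds explains the shift. Going by these compounds, whether a fluoro or methyl group at this place would raise the number as well remains open.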